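Compound 1 to Compound 3: Fluoro Gives Way to Trifluoromethoxy

The compounds below may be only part of what the source reports. "The series", "measured", "known", "first", "only" and "open" are said of these compounds alone.

Measured compounds:
compound 1 `O=C(NCN1CCC(c2cccc[n+]2[O-])CC1)c1ccc(F)c(Cl)c1`, 67% in a functional assay on HEK293 cells for agonist activity at D(4) dopamine receptor (Homo sapiens), read by FLIPR; on this read-out higher numbers stand for larger maximal responses and lower numbers for smaller maximal responses
compound 2 `O=C(NCN1CCC(c2cccc[n+]2[O-])CC1)c1ccccn1`, 40% in this assay

Compound 1 stands highest of the two; compound 2 sits a number 27 percentage points lower from compound 1 to compound 2 (beyond the scatter). Compound 3 `O=C(NCN1CCC(c2cccc[n+]2[O-])CC1)c1ccc(OC(F)(F)F)c(Cl)c1` differs from compound 1 as follows: trifluoromethoxy in place of fluoro on an aromatic carbon. Within the data shown here, no measured step touches this kind of change; the only known step swaps the whole aromatic group on the carbonyl carbon, so it gives no guide here. The expectation is therefore a step of a number 2 percentage points lower from compound 1 to compound 3 (within the scatter), not beyond the scatter, in this assay. Compound 3 is estimated at 65%, with a range from 45% to 85%.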

Compound 3, largest response reached (reported as efficacy), in percent of the reference or control that the assay uses: 33%
Compound 3: middle estimate off by 32 percentage points, on the high side; measured number below the stated range.
By their numbers in this assay, from the lowest: compounds 3 and 2 (each within the scatter of the next); then compound 1.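

In this assay, the aromatic carbon ortho to a chloro group and para to a large group turns out to be sensitive: trifluoromethoxy in place of fluoro gives a number 34 percentage points lower from compound 1 to compound 3 (beyond the scatter). The maximal response therefore depends on this single group, and not only on swapping the whole aromatic group on the carbonyl carbon. No available data explain this loss.

On these data alone, it remains open whether the loss is specific to trifluoromethoxy or would also appear with another group at this carbon, such as methoxy, an amine or a nitrile.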